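From trifluoromethyl to amino: what size of step?

The source may report more compounds than this note shows. Statements on the series, on what has been measured and on what is new or still open speak of the compounds shown alone.

Values in an ADME assay on HEK293 cells (Homo sapiens) for cytotoxicity, with a stated time of 72 h; a higher number here means that more compound is needed for the effect, a lower number that less compound is needed:
Compound 1 `CSc1ccc(NC(=O)Nc2cc(C)nc3ccccc23)cc1` – 24000 nM
Compound 2 `CC(=O)c1ccc(NC(=O)Nc2cc(C)nc3ccccc23)cc1` – > 25000 nM (a limit of the assay, not a number)
Compound 3 `Cc1cc(NC(=O)Nc2ccc(C(F)(F)F)cc2)c2ccccc2n1` – 25000 nM

For the measured compounds named here, compound 3 stands at 25000 nM in this assay and the only other exact number lies within the scatter of it, as the step of a 1.0-fold higher number from compound 1 to compound 3 (0.02 log units; within the scatter) shows. Compound 4 `Cc1cc(NC(=O)Nc2ccc(N)cc2)c2ccccc2n1` has not yet been measured. It carries amino in place of trifluoromethyl on an aromatic carbon, para to a large group amino in place of trifluoromethyl on an aromatic carbon and nothing else differs.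

The best guides are the measured swaps of a single group on an aromatic carbon. Besides the step already given, there is an at least 1.0-fold higher number from compound 1 to compound 2 (0.01 log units; that floor lies within the scatter) and also a number no higher from compound 2 to compound 3 (the limit leaves the size open) whose size stays unknown. Neither readable step goes beyond the scatter, but none of these compounds carries amino, so the new group remains untested. Resting on compound 1 and compound 3 with their step of a 1.0-fold higher number from compound 1 to compound 3 (0.02 log units; within the scatter), no step beyond the scatter is expected, and the estimated step is a 1.3-fold lower number from compound 3 to compound 4 (0.10 log units; within the scatter) in this case. Compound 4 may also return only a limit. For compound 4 the estimate is 20000 nM with an expected range from 8000 nM to 25000 nM in this assay.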

Compound 4, half-maximal effective concentration: > 25000 nM
Compound 4 gave a limit, no number; the forecaster's own chance of this, stated with the estimate: 40%; middle value at least 1.2-fold (0.09 log units) away from the limit.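

In this assay compound 4 gives > 25000 nM, which is a limit of the assay and not a number. That leaves a number no lower from compound 3 to compound 4 (the limit leaves the size open). Compound 4 adds a new kind of group to the position para to a large group: amino brings a hydrogen-bond donor and a hydrogen-bond acceptor in place of trifluoromethyl, which has neither, yet the result stays at the top of the tested range and shows no clear fall in the number needed for the effect. For the compounds shown here, the only readable step, an at least 1.0-fold higher number from compound 1 to compound 4 (0.01 log units; that floor lies within the scatter), has a floor within the scatter, and the steps to compound 2 and compound 3 cannot be read, so no readable change at this position goes beyond the scatter.

As far as these compounds go, how far compound 2 and compound 4 really lie from compound 1 and compound 3 stays unknown because the assay stops at a ceiling: the limit of > 25000 nM in this assay, at which 2 of the 4 values shown sit. Whether a carboxylic acid or a longer chain at this position would bring the number clearly down, giving a step that can be sized, remains open.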